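The source may report more compounds than this note shows. Statements on the series, on what has been measured and on what is new or still open speak of the compounds shown alone.

Of the compounds shown here, two have been measured in a physicochemical assay for lipophilicity, read by HPLC, measured as octanol-water partition (on this read-out lower numbers stand for lower lipophilicity and higher numbers for higher lipophilicity), so far. Compound 1 `COc1ccc(N(CC(=O)NCCC[Se]c2ccccc2)C(=O)/C=C/c2ccccc2)cc1` gives 3.7 in this assay, while compound 2 `COc1ccc(N(CC(=O)NCCC[Te]c2ccccc2)C(=O)c2ccccc2)cc1` gives 1.72, the lower of the two numbers by a margin beyond the scatter. The next compound, compound 3 `COc1ccc(N(CC(=O)NCCC[Te]c2ccccc2)C(=O)/C=C/c2ccccc2)cc1`, carries 2-phenylethenyl in place of phenyl on a carbonyl carbon and so differs from compound 2 only in that one place. Going by the values given here, since no measured pair shows this same change, the step is expected from the change alone: an increase in this assay from compound 2 to compound 3 of about a number 0.78 log units higher from compound 2 to compound 3 (beyond the scatter). Compound 3 is therefore estimated at 2.5 in this assay, within a range from 1.8 to 3.4.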

Compound 3, partition coefficient: 1.31
Estimate against measurement, compound 3: 1.19 log units above; the measured number lies below the stated range.
By their numbers in this assay, from the lowest: compound 3; then compound 2; then compound 1.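

In this assay, 2-phenylethenyl in place of phenyl on a carbonyl carbon gives a number 0.41 log units lower from compound 2 to compound 3 (beyond the scatter), so at this position the larger group goes with a lower number, not a higher one. With that group kept, the tellurium-bearing group in place of the selenium-bearing group on the saturated chain carbon gives a number 2.39 log units lower from compound 1 to compound 3 (beyond the scatter), a large step. Nothing at hand gives a cause for either step. The compounds shown leave open whether an amine or a longer chain on that carbonyl carbon would go the same way, and whether the change from phenyl to 2-phenylethenyl would step the same way with selenium in place of tellurium.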